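The source may hold more compounds than are shown below. What is called first, only, known or untested is meant among the compounds shown, and "the series" means these compounds.

Of the compounds shown here, three built on one shared core have been tested in a functional assay on NCI-H292 cells (Homo sapiens) for antiproliferative activity; on this read-out lower numbers stand for stronger inhibition and higher numbers for weaker inhibition. Compound 1 `Cc1ccc(N2C(=O)N/C(=C\c3ccc(O)cc3)C2=O)cc1` gives 27900 nM. Compound 3 `O=C1N/C(=C\c2ccc(O)cc2)C(=O)N1c1ccc(Br)cc1` gives 69900 nM. Compound 2 `O=C1N/C(=C\c2ccc(O)cc2)C(=O)N1c1cccc(I)c1` is different: it reaches only the limit of > 200000 nM, which is a boundary of the measurement rather than a number. This is the case described by the limit of > 200000 nM in this assay, at which 1 of the 3 values shown sits. Compound 2 therefore stands at the weak end of everything measured so far, and both steps that connect it to a numbered value lead downward or away from it: an at least 7.1-fold higher number from compound 1 to compound 2 (0.85 log units; beyond the scatter) and an at least 2.8-fold lower number from compound 2 to compound 3 (0.45 log units; beyond the scatter). The third step, a 2.5-fold higher number from compound 1 to compound 3 (0.40 log units; beyond the scatter), shows that the group on the phenyl attached to the ring nitrogen matters even between two numbered compounds.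

Compound 4 `O=C(Nc1ccc(Cl)cc1)c1cccc(N2C(=O)N/C(=C\c3ccc(O)cc3)C2=O)c1` is the next candidate. It differs from compound 2 by (4-chlorophenyl)carbamoyl in place of iodo on an aromatic carbon. Going by the values given here, no measured step changes this position by such a large group, so only the direction can be borrowed from the two steps that leave compound 2 towards stronger inhibition. The expectation is therefore a move downward, an at least 2.0-fold lower number from compound 2 to compound 4 (0.30 log units; that floor lies within the scatter), though with wide uncertainty because compound 2 gives only the limit > 200000 nM. The estimate for compound 4 is 100000 nM, expected to lie between 20000 nM and 300000 nM.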

Compound 4, half-maximal inhibitory concentration: 125000 nM
The estimate for compound 4 lay 1.3-fold (0.10 log units) below the measured number; low and high end bracket the measured number.
By their numbers in this assay, from the lowest: compound 1; then compounds 3 and 4 (each within the scatter of the next). At a limit, above all of these: compound 2.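

In this assay, putting (4-chlorophenyl)carbamoyl in place of iodo on this aromatic carbon gives an at least 1.6-fold lower number from compound 2 to compound 4 (0.20 log units; that floor lies within the scatter). On these data alone, that step is only a floor, and its true size stays unknown, since compound 2 carries a limit and not a number: the limit of > 200000 nM in this assay, at which 1 of the 4 values shown sits. Going by these compounds alone, what is new is that this position, until now seen only with a single iodine atom, still yields a measured number when it carries a far larger group with an extra six-membered aromatic ring, a hydrogen-bond donor and a hydrogen-bond acceptor, as compound 4 gives 125000 nM.

The compounds shown leave open which part of the new group goes with this result: the carbonyl and amide hydrogen that link it, the added ring, or the chlorine on that ring. A carboxylic acid or a simple amine on the same aromatic carbon, or the same carbamoyl link carrying an unsubstituted phenyl, would help separate these parts and could give a step with a number at both ends, if the partner compound also gave a number.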